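The source may report more compounds than this note shows. Statements on the series, on what has been measured and on what is new or still open speak of the compounds shown alone.

Compound 1 `Nc1nc(Cl)c(-c2ccccn2)c(N[C@@H]2C[C@H](CO)[C@@H](O)[C@H]2O)n1`, limit: > 25000 nM
Compound 2 `CNc1nc(C)c(-c2nc3ccccc3s2)c(N[C@@H]2C[C@H](CO)[C@@H](O)[C@H]2O)n1`, limit: > 25000 nM

Both were tested in an ADME assay on cells (Homo sapiens) for cytotoxicity, read by polymerase chain reaction, with a stated time of 3 days; a lower number here means that less compound is tolerated, a higher number that more compound is tolerated. For compound 1 the value > 25000 nM is a limit of the assay, not a number. For compound 2 the value > 25000 nM is likewise a limit. Within the data shown here, compound 2 thus stands at the limit of > 25000 nM in this assay, at which 2 of the 2 values shown sit, and no step between measured compounds separates it from compound 1. Compound 3 `CCOC(=O)NCCNc1nc(C)c(-c2nc3ccccc3s2)c(N[C@@H]2C[C@H](CO)[C@@H](O)[C@H]2O)n1` differs from compound 2 by ((ethoxycarbonyl)amino)methyl in place of hydrogen on a saturated chain carbon bound to a nitrogen on an aromatic ring. With both known values sitting at the limit, the step of a number no higher from compound 2 to compound 3 (the limit leaves the size open) is expected to be none beyond the scatter. Compound 3 is estimated at 25000 nM, with a range from 10000 nM to 60000 nM.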

Compound 3, half-maximal cytotoxic concentration: 12000 nM
For compound 3 the middle estimate is 2.1-fold (0.32 log units) above the measured one; low and high end bracket the measured number.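

In this assay, among these compounds, the change at this position is the first to bring a number rather than a limit: ((ethoxycarbonyl)amino)methyl in place of hydrogen on a saturated chain carbon bound to a nitrogen on an aromatic ring gives an at least 2.0-fold lower number from compound 2 to compound 3 (0.31 log units; beyond the scatter). The full size of this step stays open, as the value for compound 2 is a limit: the limit of > 25000 nM in this assay, at which 2 of the 3 values shown sit.

The compounds shown leave open whether the step belongs to the chain or to its ethoxycarbonyl end. A free amine or a carboxylic acid at the end of the chain, or a longer chain, could separate the two.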